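Aromatic Ester in Place of a Free Hydroxy Group

The compounds below may be only part of what the source reports. "The series", "measured", "known", "first", "only" and "open" are said of these compounds alone.

Compound 1 `C=C1C(=O)[C@@]23C(=O)OC[C@]4(C(=O)CCC(C)(C)[C@H]4C=O)[C@@H]2CC[C@@H]1[C@H]3O` carries a free hydroxy group on a saturated carbon of its core. Among the measured compounds shown here, in a functional assay on CaEs17 cells (Homo sapiens) for cytotoxicity, read by MTT assay, with a stated time of 72 h (a lower number here means a stronger inhibitor, a higher number a weaker inhibitor), compound 1 gives 5850 nM, the highest number among the two compounds measured so far. Its nearest neighbour is compound 2 `C=C1C(=O)[C@@]23C(=O)OC[C@]4(C(=O)CCC(C)(C)[C@H]4C=O)[C@@H]2CC[C@@H]1[C@H]3OC(=O)CC`, which in this assay gives 1400 nM. Those two differ only at that oxygen, where a propanoyl group stands in place of hydrogen, and the step was a 4.2-fold lower number from compound 1 to compound 2 (0.62 log units; beyond the scatter). Compound 3 `C=C1C(=O)[C@@]23C(=O)OC[C@]4(C(=O)CCC(C)(C)[C@H]4C=O)[C@@H]2CC[C@@H]1[C@H]3OC(=O)c1ccc(Cl)cc1` is made from compound 1 by a change at the same oxygen: (4-chlorophenyl)carbonyl in place of hydrogen on an oxygen on a saturated carbon. For the measured compounds named here, because the one measured step at this oxygen, a 4.2-fold lower number from compound 1 to compound 2 (0.62 log units; beyond the scatter), went to a lower number, a step of similar size and direction is expected for compound 3, read as a 4.9-fold lower number from compound 1 to compound 3 (0.69 log units; beyond the scatter). Compound 3 is therefore estimated at 1200 nM, with a range from 400 nM to 3600 nM.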

Compound 3, half-maximal inhibitory concentration: 2550 nM
Compound 3: middle estimate off by 2.1-fold (0.33 log units), on the low side, and the stated range covers the measured number.
By their numbers in this assay, from the lowest: compounds 2 and 3 (each within the scatter of the next); then compound 1.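

In this assay, a second ester at this oxygen also gives a lower number than the free hydroxy group of compound 1 (a 2.3-fold lower number from compound 1 to compound 3 (0.36 log units; beyond the scatter)). The direction therefore holds for two different groups on this oxygen, propanoyl and (4-chlorophenyl)carbonyl, which a single step could not show. Exchanging ethyl for 4-chlorophenyl on the carbonyl carbon gives a change that cannot be told apart from assay noise (a 1.8-fold higher number from compound 2 to compound 3 (0.26 log units; within the scatter)), so compound 2 and compound 3 read alike here. Nothing available explains why these esters differ from the free hydroxy group.

Still open, on these data alone, is whether the ester link itself matters, which a methyl ether or an amine at this carbon could test. Also open, as far as these compounds go, is whether the chlorine counts, which a plain benzoyl ester could show.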